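One Sulfonamide Swap Across Two Cores in a Cell Assay

The compounds below may be only part of what the source reports. "The series", "measured", "known", "first", "only" and "open" are said of these compounds alone.

Compound 1 `O=C1/C(=C/c2coc3ccccc3c2=O)N=C(c2ccccc2)N1c1ccc(S(=O)(=O)Nc2nccs2)cc1` and compound 3 `Cc1cc(C)nc(NS(=O)(=O)c2ccc(N3C(=O)/C(=C/c4coc5ccccc5c4=O)N=C3c3ccccc3)cc2)n1` share one core, while compound 2 `O=C1N=C(Nc2ccc(S(=O)(=O)Nc3nccs3)cc2)S/C1=C/c1coc2ccccc2c1=O` and compound 4 `Cc1cc(C)nc(NS(=O)(=O)c2ccc(NC3=NC(=O)/C(=C\c4coc5ccccc5c4=O)S3)cc2)n1` share another; the difference between the two cores is not broken down here. In a functional assay on MCF7 cells (Homo sapiens) for cytotoxicity, read by sulforhodamine B assay, with a stated time of 72 h (on this read-out higher numbers stand for weaker inhibition and lower numbers for stronger inhibition), compound 1 gives 88500 nM. In this assay compound 3 gives 99700 nM. The change 4,6-dimethylpyrimidin-2-yl in place of 1,3-thiazol-2-yl on a sulfonamide nitrogen therefore made a step of a 1.1-fold higher number from compound 1 to compound 3 (0.05 log units; within the scatter). For compound 2 this assay reports only a limit, > 100000 nM. The same change, (4,6-dimethylpyrimidin-2-yl in place of 1,3-thiazol-2-yl on a sulfonamide nitrogen), leads from compound 2 to compound 4. Compound 4 is expected to give 120000 nM, which means an expected step that the limit leaves unreadable from compound 2 to compound 4. This expectation rests on the measured step of a 1.1-fold higher number from compound 1 to compound 3 (0.05 log units; within the scatter) and on the limit (the limit of > 100000 nM in this assay, at which 1 of the 3 values shown sits), at which compound 2 already sits, so a limit rather than a number is likely again.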

Compound 4, half-maximal inhibitory concentration: > 100000 nM
Compound 4 ended at the assay's limit; the forecaster's own chance of this, stated with the estimate: 80%; the middle value is on the limit's open side.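

Going by these compounds alone, compound 2 and compound 4 both end at a limit of this assay rather than at a number, so no step between them can be read. From the compounds shown here alone, whether the sulfonamide swap changes anything on their core stays open.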